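This account rests on a few compounds, and the source may have more. Where it says the series, first, only, none or still open, it means among the compounds named here.

Measured compounds:
compound 1, `Cc1ccc(C(=O)Nc2cc(-c3ccccc3)nn2-c2ccccc2)cc1`, 780 nM
compound 2, `COc1cccc(-c2cc(NC(=O)c3ccccc3)n(-c3ccccc3)n2)c1`, 3200 nM
compound 3, `O=C(Nc1cc(-c2ccccc2)nn1-c1cccc(Br)c1)c1ccccc1`, a limit, > 10000 nM

In an assay on HEK293 cells for displacement of a labelled ligand from metabotropic glutamate receptor 5 (Rattus norvegicus) (a higher number here means a weaker inhibitor, a lower number a stronger inhibitor), compound 1 gives 780 nM and stands lowest of the two numbers in hand. Compound 2 gives 3200 nM, a higher number that lies beyond the usual scatter, so compound 1 is the stronger of the two. Compound 3 returns no number in this assay but only (the limit of > 10000 nM in this assay, at which 1 of the 3 values shown sits), so it is set aside when the sizes of steps are weighed.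

Within the data shown here, no pair of measured compounds differs in one place only, so no measured step is available to anchor the change now under consideration.

The next compound is compound 4, `O=C(Nc1cc(-c2ccccc2)nn1-c1ccccc1)C1CCCC1`. It departs from compound 1 in one place: cyclopentyl in place of 4-methylphenyl on a carbonyl carbon. The aromatic six-membered ring carried on the carbonyl carbon in compound 1 is thereby exchanged for a non-aromatic five-membered ring of the same kind of atoms.

Among the measured compounds shown here, with no measured step of this type to lean on, the expected step from compound 1 to compound 4 is a 3.2-fold higher number from compound 1 to compound 4 (0.51 log units; beyond the scatter), a weakening of moderate size in this assay, with the uncertainty stretching from within the scatter to a clear loss. Compound 4 is accordingly estimated at 2500 nM, in a range from 700 nM to 9000 nM.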

Compound 4, inhibition constant: 11600 nM
Beside the measured number, compound 4's estimate is 4.6-fold (0.67 log units) below it; measured number above the stated range.
By their numbers in this assay, from the lowest: compound 1; then compound 2; then compound 4.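

Cyclopentyl in place of 4-methylphenyl on a carbonyl carbon is the first one-place change in this series that can be read, and in this assay it gives a 15-fold higher number from compound 1 to compound 4 (1.17 log units; beyond the scatter), a large step. With the rest of compound 1 kept, the group on this carbonyl carbon therefore matters in this assay: a five-membered non-aromatic ring of carbon only does not serve in place of the six-membered aromatic ring of 4-methylphenyl. Compound 3 adds no size of step to this reading, as its entry is a limit and not a number: the limit of > 10000 nM in this assay, at which 1 of the 4 values shown sits.

Open, from the compounds shown here alone, is which part of the exchange carries the step, since ring size, aromatic character and the methyl group all change together in this single pair. A cyclohexyl group or a pyridyl ring on the same carbonyl carbon would begin to separate these, and a single step says nothing yet about how far other groups at this position would move the number.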